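A few compounds are considered here, and "the series" means these few. Any claim that something is new, unique, unknown or untested is made for them only; others in the source may bear on it.

Of the compounds shown here, two built on the same core have been measured in a functional assay on NSCLC cells (Homo sapiens) for cytotoxicity, with a stated time of 48 h; a higher number here means a weaker inhibitor of growth, a lower number a stronger inhibitor of growth. Going by the values given here, compound 1 `COc1ccc(CN2C(=O)/C(=C\c3cc(OC)c(OC)c(OC)c3)c3ccccc32)cc1` gives 9300 nM in this assay, the lower of the two numbers known so far. Compound 2 `COc1cc(/C=C2\C(=O)N(C)c3ccc(Cl)cc32)cc(OC)c1OC` differs from compound 1 in several places. In this assay compound 2 gives 28200 nM, a gap that lies beyond the usual scatter of repeated measurements. Compound 3 `COc1cc(/C=C2\C(=O)N(Cc3ccc(Cl)cc3)c3ccccc32)cc(OC)c1OC` has not yet been tested. It differs from compound 1 at a single spot: chloro in place of methoxy on an aromatic carbon, so that the 4-methoxybenzyl group becomes a 4-chlorobenzyl group. Among the compounds with values here, no measured pair shows the effect of this exact swap, so the expectation rests on compound 1 alone. Only a small step is expected, none beyond the scatter: a 1.3-fold higher number from compound 1 to compound 3 (0.11 log units; within the scatter). Compound 3 is therefore estimated at 12000 nM in this assay, within a range from 4000 nM to 36000 nM.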

Compound 3, concentration for total growth inhibition: 14400 nM
Compound 3: middle estimate off by 1.2-fold (0.08 log units), on the low side; low and high end bracket the measured number.
By their numbers in this assay, from the lowest: compounds 1, 3 and 2 (each within the scatter of the next, the first and the last beyond it).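

Going by these compounds alone, replacing the 4-methoxybenzyl group with a 4-chlorobenzyl group gives a 1.5-fold higher number from compound 1 to compound 3 (0.19 log units; within the scatter) in this assay and is the only single-place change read so far, since compound 2 differs from compound 1 in several places. At this spot on an aromatic carbon, para to a large group, the read-out does not separate methoxy from chloro, even though the two groups differ in their atoms and chloro brings no hydrogen-bond acceptor. No measured evidence is at hand to explain why these two compounds read alike.

From the compounds shown here alone, how an amine, a carboxylic acid or a longer alkoxy chain would read at this spot remains open. So does whether chloro and methoxy would also read alike on a differently substituted version of the shared core.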